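Changing the amide heterocycle in a weakly active series

The source may hold more compounds than are shown below. What is called first, only, known or untested is meant among the compounds shown, and "the series" means these compounds.

Compound 1 `Cn1c(/C=C2\SC(=O)N(CC(=O)Nc3cc(C(C)(C)C)on3)C2=O)nc2ccccc21` has been tested in a functional assay on PC-3 cells (Homo sapiens) for inhibition, read by MTT assay, with a stated time of 48 h; on this read-out lower numbers stand for stronger inhibition and higher numbers for weaker inhibition; in that assay compound 1 reaches only the assay limit, > 50000 nM. Compound 2 `Cn1c(/C=C2\SC(=O)N(CC(=O)N3CCCCC3)C2=O)nc2ccccc21` likewise gives only the limit in this assay, > 50000 nM. The step that the two limits leave unreadable from compound 1 to compound 2 therefore cannot be read, since both values sit at the limit of > 50000 nM in this assay, at which 2 of the 2 values shown sit. Compound 3 `Cn1c(/C=C2\SC(=O)N(CC(=O)Nc3nc(-c4ccccc4)cs3)C2=O)nc2ccccc21` differs from compound 1 by 4-phenyl-1,3-thiazol-2-yl in place of 5-(tert-butyl)-1,2-oxazol-3-yl on an amide-type nitrogen. For the measured compounds named here, no measured step tells how this change acts in this assay, so no step beyond the scatter is expected in either direction. Compound 3 is expected to give 50000 nM (range 15000 nM to 150000 nM), an expected step of a number no higher from compound 1 to compound 3 (the limit leaves the size open).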

Compound 3, half-maximal inhibitory concentration: 39900 nM
The estimate for compound 3 lay 1.3-fold (0.10 log units) above the measured number; the range from low to high includes it.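

In this assay, for the compounds shown here, compound 3 is the first compound here to give a real number, 39900 nM, and not a limit. On this amide-type nitrogen, 4-phenyl-1,3-thiazol-2-yl in place of 5-(tert-butyl)-1,2-oxazol-3-yl brings an at least 1.2-fold lower number from compound 1 to compound 3 (0.09 log units; that floor lies within the scatter), so the change cannot yet be called a real gain. Most values still give no size to compare: the limit of > 50000 nM in this assay, at which 2 of the 3 values shown sit.

From the compounds shown here alone, it remains open whether the change follows from the thiazole or from its phenyl ring. Also open, going by these compounds, is what a plain 1,3-thiazol-2-yl, or a carboxylic acid on the phenyl ring, would give in this assay.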